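Dropping one chloro from a dichlorophenyl arylidene diketopiperazine

A few compounds are considered here, and "the series" means these few. Any claim that something is new, unique, unknown or untested is made for them only; others in the source may bear on it.

Measured compounds:
- compound 1, `COc1ccccc1/C=c1\c(=O)[nH]/c(=C/c2cccc(Cl)c2Cl)c(=O)n1C`: 200 nM
- compound 2, `C=CCn1c(=O)/c(=C\c2ccc(Cl)c(Cl)c2)[nH]c(=O)/c1=C\c1ccccc1`: "not active" (no number reported)
- compound 3, `C=CCn1c(=O)/c(=C\c2cccc(F)c2)[nH]c(=O)/c1=C\c1ccccc1OC`: 9100 nM

Three analogues of the shared core have been examined in a functional assay on HeLa cells (Homo sapiens) for cytotoxicity, read by CCK-8 assay, with a stated time of 72 h; on this read-out lower numbers stand for stronger inhibition and higher numbers for weaker inhibition. Compound 1 gives 200 nM there, the lowest of the two numbers reported. Compound 3 gives 9100 nM, a number higher than that of compound 1 by a margin that goes well beyond the usual scatter. Compound 2 is recorded as "not active" (no number reported) with no number attached. No pair among these three differs in a single place, so no single step can be read from them; compound 1 and compound 3 differ at both aryl groups and at the substituent on the ring nitrogen at once.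

The next compound, compound 4, `COc1ccccc1/C=c1\c(=O)[nH]/c(=C/c2ccccc2Cl)c(=O)n1C`, differs from compound 1 in one place only: hydrogen in place of chloro on an aromatic carbon. The remaining comparison, compound 1 at 200 nM against compound 3 at 9100 nM, carries several changes together and gives no direct guide for removing one chloro alone. In this assay the step of a 2.5-fold higher number from compound 1 to compound 4 (0.40 log units; beyond the scatter) is expected to be small, toward a higher number, and possibly within the scatter. Compound 4 is estimated at 500 nM, with a range from 150 nM to 2000 nM.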

Compound 4, half-maximal inhibitory concentration: 300 nM
The estimate for compound 4 lay 1.7-fold (0.22 log units) above the measured number, and the stated range covers the measured number.
By their numbers in this assay, from the lowest: compounds 1 and 4 (each within the scatter of the next); then compound 3.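

For the compounds shown here, the change from 2,3-dichlorophenyl to 2-chlorophenyl amounts, in this assay, to a 1.5-fold higher number from compound 1 to compound 4 (0.18 log units; within the scatter) and is the first step in this set that can be read on its own. At this place, an aromatic carbon ortho to a chloro group, hydrogen can stand in for chloro without a difference that exceeds the usual variation between repeated measurements, so this one chlorine is not needed for the activity of compound 1 in this assay. No measured property of these compounds bears on the result, and the data offer no explanation for it.

What the compounds leave open is whether the chloro that remains in compound 4 can also give way to hydrogen, and whether a methyl, a hydroxyl or an amine on the aromatic carbon that now carries hydrogen would read the same. Also open, going by these compounds, is what an allyl group in place of the methyl on the ring nitrogen would do on its own, with both aryl groups held as they are in compound 4.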